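A few compounds are considered here, and "the series" means these few. Any claim that something is new, unique, unknown or untested is made for them only; others in the source may bear on it.

In a functional assay (trachea) with Cavia porcellus as the target (on this read-out lower numbers stand for stronger inhibition and higher numbers for weaker inhibition), compound 1 (`CC(C)n1nc(-c2cccnc2)c2ccccc2c1=O`) gives 3090 nM and compound 2 (`CCCCn1nc(-c2cccnc2)c2ccccc2c1=O`) gives 2290 nM. The step of a 1.3-fold lower number from compound 1 to compound 2 (0.13 log units; within the scatter) stays within the scatter. Compound 3 (`CC(=O)Cn1nc(-c2cccnc2)c2ccccc2c1=O`) has the highest number of the three at 40700 nM, with a 13-fold higher number from compound 1 to compound 3 (1.12 log units; beyond the scatter) and an 18-fold higher number from compound 2 to compound 3 (1.25 log units; beyond the scatter). Compound 4 (`COCCn1nc(-c2cccnc2)c2ccccc2c1=O`) has methoxymethyl in place of acetyl on a saturated chain carbon bound to an aromatic nitrogen. The closest measured change is an 18-fold higher number from compound 2 to compound 3 (1.25 log units; beyond the scatter), which concerns acetyl at that same place. Compound 4 also loses acetyl, but gains methoxymethyl rather than propyl, so only part of that large step is expected to return in this assay. The expected step is a 5.1-fold lower number from compound 3 to compound 4 (0.71 log units; beyond the scatter). Compound 4 is estimated at 8000 nM, with an expected range of 2500 nM to 25000 nM.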

Compound 4, half-maximal inhibitory concentration: 9330 nM
Beside the measured number, compound 4's estimate is 1.2-fold (0.07 log units) below it; measured number inside the range.
By their numbers in this assay, from the lowest: compounds 2 and 1 (each within the scatter of the next); then compound 4; then compound 3.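

In this assay, methoxymethyl in place of acetyl gives a 4.4-fold lower number from compound 3 to compound 4 (0.64 log units; beyond the scatter), although the two groups match in heavy atoms and hydrogen-bond acceptors, so those counts alone do not set the number at this place. Both oxygen-bearing chains still sit on the weaker side of the alkyl groups, with a 4.1-fold higher number from compound 2 to compound 4 (0.61 log units; beyond the scatter) and a 3.0-fold higher number from compound 1 to compound 4 (0.48 log units; beyond the scatter). Nothing available explains these differences. Open, on these data alone, is whether a terminal hydroxyl, an amine or a longer ether chain at this place would come closer to butyl.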